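This account rests on a few compounds, and the source may have more. Where it says the series, first, only, none or still open, it means among the compounds named here.

Compound 2 `COc1ccc(N/N=C2\CCC(C)n3c2ncc(C(=O)O)c3=O)cc1` stands with the lowest of the two numbers in a functional assay on the whole organism for inhibition, with Rattus norvegicus as the target (a lower number here means that less compound is needed, a higher number that more compound is needed for the effect), giving 7.6 umol/kg. Compound 3 `Cc1cccc(N/N=C2\CCC(C)n3c2ncc(C(=O)O)c3=O)c1` gives 72.5 umol/kg in this assay, a change of a 9.5-fold higher number from compound 2 to compound 3 (0.98 log units; beyond the scatter). Compound 1 `CC1CC/C(=N\Nc2ccccc2F)c2ncc(C(=O)O)c(=O)n21` reaches only the limit of this assay, > 1000 umol/kg (the limit of > 1000 umol/kg in this assay, at which 1 of the 3 values shown sits). From that limit, the step from compound 1 to compound 2 is an at least 130-fold lower number from compound 1 to compound 2 (2.11 log units; beyond the scatter), and the step from compound 1 to compound 3 is an at least 13-fold lower number from compound 1 to compound 3 (1.13 log units; beyond the scatter). Compound 4 `CNC(=O)c1ccc(N/N=C2\CCC(C)n3c2ncc(C(=O)O)c3=O)cc1` differs from compound 2 by methylcarbamoyl in place of methoxy on an aromatic carbon. Every measured step changes the group on the amine nitrogen, and none exchanges methoxy for methylcarbamoyl; the measured step from compound 2 to compound 3 shows that giving up the methoxy can cost a modest amount, so a modest rise is expected, a 2.6-fold higher number from compound 2 to compound 4 (0.42 log units; beyond the scatter). Compound 4 is therefore estimated at 20 umol/kg in this assay, between 4 umol/kg and 100 umol/kg.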

Compound 4, dose for 50% inhibition: > 100 umol/kg
Compound 4: a limit, no number (the forecaster's own chance of this, stated with the estimate: 10%); middle value at least 5.0-fold (0.69 log units) away from the limit.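

Among these compounds, replacing the methoxy with methylcarbamoyl on the aromatic carbon, para to a large group, gives an at least 13-fold higher number from compound 2 to compound 4 (1.11 log units; beyond the scatter), the first step here that changes a substituent on the aryl ring while keeping that ring's para placement. The size of this step rests on a limit, not a number: the limit of > 100 umol/kg in this assay, at which 1 of the 4 values shown sits. The change adds a hydrogen-bond donor and two heavy atoms, and the compounds do not separate these two differences.

On these data alone, it remains open whether an amine, a hydroxyl or a methyl ester at this position would keep the low number of compound 2 in this assay.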